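A few compounds are considered here, and "the series" means these few. Any claim that something is new, unique, unknown or untested is made for them only; others in the source may bear on it.

Going by the values given here, compound 2 `COc1ccccc1NCC(=O)Oc1ccc2c(C)cc(=O)oc2c1` stands at the low end of the two numbers so far: in a functional assay on the whole organism (strain Wistar albino) for inhibition, with Rattus norvegicus as the target, read by paw edema, with stated times of 30 min and 4 h, at a dose of 20 mg/kg by the oral route (a higher number here means more inhibition at the dose given (going by the name of the read-out), a lower number less inhibition), compound 2 gives 19.4%, while compound 1 `COc1ccc(NCC(=O)Oc2ccc3c(C)cc(=O)oc3c2)cc1` gives 28.8%. Among the compounds with values here, the single recorded step, a number 9.4 percentage points lower from compound 1 to compound 2 (within the scatter), exchanges 2-methoxyphenyl for 4-methoxyphenyl on the amine nitrogen and stays inside the scatter. Compound 3 `Cc1cc(=O)oc2cc(OC(=O)CNc3ccccc3[N+](=O)[O-])ccc12` differs from compound 2 by nitro in place of methoxy on an aromatic carbon. Within the data shown here, no measured step puts a nitro in place of a methoxy, so nothing recorded bears directly on this change. Compound 3 is therefore expected to stay close to compound 2, with an estimated step of a number 0.6 percentage points higher from compound 2 to compound 3 (within the scatter) and an estimated value of 20%, ranging from 8% to 34%.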

Compound 3, a percentage reported as inhibition, in the whole organism at one dose (the size of the read-out at that dose, not a potency): 15.2%
Compound 3: middle estimate off by 4.8 percentage points, on the high side; measured number inside the range.
By their numbers in this assay, from the lowest: compounds 3, 2 and 1 (each within the scatter of the next, the first and the last beyond it).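

In this assay, the step of a number 4.2 percentage points lower from compound 2 to compound 3 (within the scatter) shows that replacing the group itself on this aromatic carbon, ortho to a large group, does not move the number beyond the scatter. The earlier step had only changed where methoxy sat on the phenyl ring, whereas this one exchanges methoxy for nitro at a fixed place. Nothing available explains this result. As far as these compounds go, whether an amine or a chlorine at this place would separate from compound 2 stays open. So does whether 4-nitrophenyl on the amine nitrogen would read like compound 1.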